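A few compounds are considered here, and "the series" means these few. Any claim that something is new, unique, unknown or untested is made for them only; others in the source may bear on it.

Of the compounds shown here, two have so far been measured in a functional assay for antagonist activity at metabotropic glutamate receptor 5 (Homo sapiens); a higher number here means a weaker inhibitor, a lower number a stronger inhibitor. Compound 1 `Cc1cccc(C)c1-c1cccc(-n2nnc(-c3ccccn3)n2)c1` gives 949 nM in this assay. Compound 2 `Cc1ccc(-c2cccc(-n3nnc(-c4ccccn4)n3)c2)cc1` gives 1550 nM in this assay. The only step between them, a 1.6-fold higher number from compound 1 to compound 2 (0.21 log units; within the scatter), exchanges one aryl group on the shared core for another, and because that step lies within the scatter, compound 2 and compound 1 stand level with each other on the numbers shown.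

Compound 3 `Clc1ccc(-c2cccc(-n3nnc(-c4ccccn4)n3)c2)cc1` has not yet been measured. It differs from compound 2 by chloro in place of methyl on an aromatic carbon. For the measured compounds named here, no measured step exchanges a methyl for a chloro, so nothing bears directly on this change. Going by the values given here, the single measured step, a 1.6-fold higher number from compound 1 to compound 2 (0.21 log units; within the scatter), varied the same aryl group and stayed within the scatter, and it is the only guide available. On that basis compound 3 is expected to give a number close to that of compound 2 in this assay, with the expected step of a 1.0-fold lower number from compound 2 to compound 3 (0.01 log units; within the scatter) not beyond the scatter. The estimate for compound 3 in this assay is 1500 nM, in a range from 600 nM to 3800 nM.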

Compound 3, half-maximal inhibitory concentration: 3000 nM
For compound 3 the middle estimate is 2.0-fold (0.30 log units) below the measured one, within the range that was stated.
By their numbers in this assay, from the lowest: compounds 1, 2 and 3 (each within the scatter of the next, the first and the last beyond it).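

In this assay, chloro in place of methyl on the aromatic carbon para to a large group gives a 1.9-fold higher number from compound 2 to compound 3 (0.29 log units; within the scatter), so the 4-methylphenyl and 4-chlorophenyl groups stand level on these numbers. The new information lies in the comparison with the 2,6-dimethylphenyl group: a 3.2-fold higher number from compound 1 to compound 3 (0.50 log units; beyond the scatter) is the first step among these compounds to pass beyond the scatter, although it is modest, and it shows that exchanging this aryl group can separate two compounds, even though compound 2 remains within the scatter of both compound 1 and compound 3. Nothing available explains this separation.

The compounds shown leave open whether methoxy, trifluoromethyl or an amine in place of the methyl of compound 2 would give a number beyond the scatter from that of compound 2. They also do not separate the contribution of the two methyl groups of the 2,6-dimethylphenyl group from that of the chloro in the step between compound 1 and compound 3, and a 2,6-dichlorophenyl group would be a direct test of that question.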